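A Spiro-Cyclopropane Lactam on a Soluble Core

The source may hold more compounds than are shown below. What is called first, only, known or untested is meant among the compounds shown, and "the series" means these compounds.

Compound 1 `Cc1nccn1-c1cnc(NCc2c(F)ccc3c2CCO3)c2cn[nH]c(=O)c12` gives 7000 nM in a physicochemical assay for solubility, read by LC-MS, in phosphate buffer, with a stated time of 24 h, at pH 7.4; a lower number here means a less soluble compound, a higher number a more soluble compound.
Compound 2 `O=C1CCCN1c1cnc(NCc2c(F)ccc3c2CCO3)n2cnnc12` gives 640000 nM.
Compound 3 `Cc1nc(CN(C)C)ccc1-c1cnc(NCc2c(F)ccc3c2CCO3)c2cn[nH]c(=O)c12` reaches > 1000000 nM, which is a limit of the assay rather than a number.

Of the two compounds with numbers, compound 2 stands highest, and compound 1 sits far lower in this assay. Going by the values given here, the only measured one-place step, an at least 140-fold higher number from compound 1 to compound 3 (2.15 log units; beyond the scatter), concerns a different swap at a different position, so no measured step bears directly on the change from compound 2 to compound 4 `O=C1CC2(CC2)CN1c1cnc(NCc2c(F)ccc3c2CCO3)n2cnnc12`: a group of 8 heavy atoms (6 carbon, 1 nitrogen, 1 oxygen; one three-membered non-aromatic ring of carbon only, one five-membered non-aromatic ring with 1 hetero atom) in place of a group of 6 heavy atoms (4 carbon, 1 nitrogen, 1 oxygen; one five-membered non-aromatic ring with 1 hetero atom), on an aromatic carbon. With nothing to lean on, the expectation is a modest fall in this assay, about at the edge of the scatter, a 2.1-fold lower number from compound 2 to compound 4 (0.33 log units; beyond the scatter). Compound 4 is therefore expected near 300000 nM, between 100000 nM and 900000 nM.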

Compound 4, solubility: 130000 nM
Beside the measured number, compound 4's estimate is 2.3-fold (0.36 log units) above it; low and high end bracket the measured number.
By their numbers in this assay, from the lowest: compound 1; then compound 4; then compound 2. At a limit, above all of these: compound 3.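

In this assay, going by these compounds alone, this is the first measured step at this position, on an aromatic carbon of the ring that carries the lactam. Setting a three-membered carbon ring onto the 2-oxopyrrolidin-1-yl group gives a 4.9-fold lower number from compound 2 to compound 4 (0.69 log units; beyond the scatter), so this position responds to a small addition of carbon. Nothing measured here explains that fall.

From the compounds shown here alone, it remains open whether the step follows from the three-membered ring itself or simply from the added carbon atoms, which a gem-dimethyl lactam could help to separate. Going by these compounds, how a lactam bearing a carboxylic acid or an amine would behave at this position is also open.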